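Dropping the ethoxy from compound 1: a plain phenyl arm

The source may hold more compounds than are shown below. What is called first, only, known or untested is meant among the compounds shown, and "the series" means these compounds.

Three compounds share one core and differ only in the aryl group attached to it. Compound 1 `CCOc1ccc(-c2ccc3ncn(-c4cc(OC)c(OC)c(OC)c4)c3c2)cc1` gives 2970 nM in a functional assay on SGC-7901 cells (Homo sapiens) for antiproliferative activity, read by MTT assay, with a stated time of 72 h; on this read-out higher numbers stand for weaker inhibition and lower numbers for stronger inhibition. Compound 2 `COc1ccccc1-c1ccc2ncn(-c3cc(OC)c(OC)c(OC)c3)c2c1` gives 5050 nM, and compound 3 `COc1ccc(-c2ccc3ncn(-c4cc(OC)c(OC)c(OC)c4)c3c2)cc1F` gives 430 nM. Among these three numbers compound 1 stands second highest: the step of a 1.7-fold higher number from compound 1 to compound 2 (0.23 log units; within the scatter) is within the scatter, whereas the step of a 6.9-fold lower number from compound 1 to compound 3 (0.84 log units; beyond the scatter) is a modest gain and the step of a 12-fold lower number from compound 2 to compound 3 (1.07 log units; beyond the scatter) a large one.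

Compound 4 `COc1cc(-n2cnc3ccc(-c4ccccc4)cc32)cc(OC)c1OC` is compound 1 with the change (hydrogen in place of ethoxy on an aromatic carbon). For the measured compounds named here, no measured step removes the ethoxy outright; the measured steps only swap one substituted aryl for another, and the two that move beyond the scatter both end at compound 3. They give no direct guide, so a change within the scatter or a small loss is expected, with the step of a 1.2-fold higher number from compound 1 to compound 4 (0.07 log units; within the scatter) as the estimate. In this assay compound 4 is expected to give 3500 nM, between 1200 nM and 10000 nM.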

Compound 4, half-maximal inhibitory concentration: 290 nM
The estimate for compound 4 lay 12-fold (1.08 log units) above the measured number; the whole stated range lies above it.
By their numbers in this assay, from the lowest: compounds 4 and 3 (each within the scatter of the next); then compounds 1 and 2 (each within the scatter of the next).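

In this assay the ethoxy turns out not to be needed at this place: a bare phenyl arm gives a 10-fold lower number from compound 1 to compound 4 (1.01 log units; beyond the scatter) and removing the methoxy of compound 2 gives a 17-fold lower number from compound 2 to compound 4 (1.24 log units; beyond the scatter), so in both cases the unsubstituted arm inhibits far more strongly. Compound 3 goes against any rule that substituents here simply cost activity, since stripping its 3-fluoro-4-methoxyphenyl arm down to phenyl gives only a 1.5-fold lower number from compound 3 to compound 4 (0.17 log units; within the scatter), which is no real change. No measurement at hand explains why these arms differ.

From the compounds shown here alone, what remains open is whether a lone methoxy at the place of the ethoxy would behave like the ethoxy or like hydrogen. Going by these compounds, it is also open how an amine, a carboxylic acid or a single fluorine would fare there.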